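Solubility of a Thiophene Thioether Analogue

The source may report more compounds than this note shows. Statements on the series, on what has been measured and on what is new or still open speak of the compounds shown alone.

Measured compounds:
- Compound 1 `O=C1O[C@@H](CN2CCCCC2)CN1c1ccc(-n2cc(-c3ccccn3)cn2)c(F)c1`: 219000 nM
- Compound 2 `O=C1CNC(=O)N1C[C@H]1CN(c2ccc(-n3cc(-c4ccccn4)cn3)c(F)c2)C(=O)O1`: 1630000 nM

In a physicochemical assay for solubility, read by HPLC, with a stated time of 24 h (on this read-out higher numbers stand for higher solubility and lower numbers for lower solubility), compound 2 gives the highest number of the two, with compound 1 the nearest at a 7.4-fold higher number from compound 1 to compound 2 (0.87 log units; beyond the scatter). Compound 3 `O=C1O[C@@H](CSc2cccs2)CN1c1ccc(-n2cc(-c3ccccn3)cn2)c(F)c1` has not yet been measured. It differs from compound 2 by (thiophen-2-yl)sulfanyl in place of 2,5-dioxoimidazolidin-1-yl on a saturated chain carbon bound to a saturated ring carbon.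

For the measured compounds named here, only one measured step exists, and it concerns a different exchange at the same place: the step of a 7.4-fold higher number from compound 1 to compound 2 (0.87 log units; beyond the scatter) shows how much the number moved when a piperidin-1-yl group gave way to the 2,5-dioxoimidazolidin-1-yl group. Going by the values given here, no measured step covers a (thiophen-2-yl)sulfanyl group, so the direction and size of the coming step must be judged from the fact that the group now leaving is the one that went with the highest number seen. On that basis the solubility of compound 3 is expected to fall in this assay, with an estimated step of an 82-fold lower number from compound 2 to compound 3 (1.91 log units; beyond the scatter). The estimated value for compound 3 is 20000 nM, with a range from 3000 nM to 150000 nM.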

Compound 3, solubility: 8500 nM
Compound 3: middle estimate off by 2.4-fold (0.37 log units), on the high side; the measured number falls inside the stated range.
By their numbers in this assay, from the lowest: compound 3; then compound 1; then compound 2.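

The position on a saturated chain carbon bound to a saturated ring carbon now proves able to move the number in this assay in both directions from piperidin-1-yl, since a 26-fold lower number from compound 1 to compound 3 (1.41 log units; beyond the scatter) runs opposite to the earlier rise seen with 2,5-dioxoimidazolidin-1-yl. The exchange of the two groups from the ends of this range gives a 190-fold lower number from compound 2 to compound 3 (2.28 log units; beyond the scatter), and it replaces a non-aromatic ring carrying 1 hydrogen-bond donor with an aromatic ring attached through sulfur and carrying 0 donors. All three compounds share the same core and differ only here, so the order of compound 3, then compound 1, then compound 2 belongs to this one place, although no measurement available here explains that order.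

The sulfur link and the thiophene ring enter together, so the compounds shown leave open how much of the fall goes with each part. A phenylsulfanyl group would keep the sulfur and change the ring, a (thiophen-2-yl)oxy group would keep the ring and change the link, and a carboxylic acid or morpholin-4-yl group would test this position with quite different atoms.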